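A few compounds are considered here, and "the series" means these few. Any claim that something is new, unique, unknown or untested is made for them only; others in the source may bear on it.

Three members of one series have been measured so far. Compound 1 `COc1ccc([C@H]2CC(c3cc4ccccc4oc3=O)=NN2c2ccccc2)cc1` gives 24.8% in a functional assay on the whole organism (strain albino) for inhibition, with Rattus norvegicus as the target, read by paw edema, with stated times of 1 h and 2 h, at a dose of 200 mg/kg by the oral route; on this read-out higher numbers stand for more inhibition at the one dose given (going by the name of the read-out) and lower numbers for less inhibition. Compound 2 `O=c1oc2ccccc2cc1C1=NN(c2ccccc2)[C@@H](/C=C/c2ccccc2)C1` gives 26.7% in this assay, and compound 3 `Cc1ccc([C@H]2CC(c3cc4ccccc4oc3=O)=NN2c2ccccc2)cc1` gives 30.1% in this assay. Compound 3 shows the highest of the three numbers, yet its gaps to the others, a number 3.4 percentage points higher from compound 2 to compound 3 (within the scatter) and a number 5.3 percentage points higher from compound 1 to compound 3 (within the scatter), both lie within the scatter, so the three compounds cannot be told apart on these data. Compound 4 `O=c1oc2ccccc2cc1C1=NN(c2ccccc2)[C@@H](c2ccc(O)cc2)C1` has not been measured; it differs from compound 3 in one place: hydroxy in place of methyl on an aromatic carbon. The step that bears most on this change is the earlier exchange at the same aromatic carbon, a number 5.3 percentage points higher from compound 1 to compound 3 (within the scatter), which stayed within the scatter; the exchange on the saturated ring carbon, a number 1.9 percentage points higher from compound 1 to compound 2 (within the scatter), was likewise small. The account therefore expects no step beyond the scatter in this assay, namely a number 2.1 percentage points lower from compound 3 to compound 4 (within the scatter). Compound 4 is estimated at 28%, within a range from 17% to 39%.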

Compound 4, a percentage reported as inhibition, in the whole organism at one dose (the size of the read-out at that dose, not a potency): 28.8%
Beside the measured number, compound 4's estimate is 0.8 percentage points below it, and the stated range covers the measured number.
By their numbers in this assay, from the lowest: compounds 1, 2, 4 and 3 (each within the scatter of the next).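

At the aromatic carbon para to a large group, hydroxy in place of methyl brings in a hydrogen-bond donor and a hydrogen-bond acceptor, yet in this assay the change gives a number 1.3 percentage points lower from compound 3 to compound 4 (within the scatter). Hydrogen in place of methyl on the oxygen gives a number 4 percentage points higher from compound 1 to compound 4 (within the scatter), so methyl, methoxy and hydroxy at this position cannot be told apart, and 4-hydroxyphenyl in place of 2-phenylethenyl on the saturated ring carbon likewise gives only a number 2.1 percentage points higher from compound 2 to compound 4 (within the scatter). No measurement on these compounds offers an explanation for how close these numbers lie. The compounds shown leave open whether an amine or a carboxylic acid at this aromatic carbon would give a step beyond the scatter. They also leave open whether a change elsewhere on the shared core would do so.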